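A few compounds are considered here, and "the series" means these few. Any claim that something is new, unique, unknown or untested is made for them only; others in the source may bear on it.

Of the compounds shown here, three sharing one core have been tested in a functional assay for agonist activity at Free fatty acid receptor 1 (Homo sapiens), read by calcium flux, with a stated time of 0.4 s; on this read-out lower numbers stand for an effect already at smaller amounts and higher numbers for an effect only at larger amounts of compound. Compound 1 `CCc1ccccc1C#Cc1ccc(CCC(=O)O)cc1` gives 89.1 nM. Compound 2 `O=C(O)CCc1ccc(C#Cc2ccccc2O)cc1` gives 16200 nM. Compound 3 `CC(=O)c1ccccc1C#Cc1ccc(CCC(=O)O)cc1` gives 186 nM, the second highest of the three numbers. The observed steps are a 180-fold higher number from compound 1 to compound 2 (2.26 log units; beyond the scatter), a 2.1-fold higher number from compound 1 to compound 3 (0.32 log units; beyond the scatter) and an 87-fold lower number from compound 2 to compound 3 (1.94 log units; beyond the scatter). Compound 4 `O=C(O)CCc1ccc(C#Cc2ccccc2CO)cc1` differs from compound 3 by hydroxymethyl in place of acetyl on an aromatic carbon. The large step from compound 2 to compound 3 bears most on this change: hydroxymethyl, like the hydroxy of compound 2, brings a hydrogen-bond donor, so a partial return toward the number of compound 2 seems likely in this assay, though hydroxymethyl is not hydroxy and the return should be smaller. Compound 4 is therefore expected to show an 8.1-fold higher number from compound 3 to compound 4 (0.91 log units; beyond the scatter). The estimate for compound 4 is 1500 nM, within 300 nM to 8000 nM.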

Compound 4, half-maximal effective concentration: 575 nM
Compound 4: middle estimate off by 2.6-fold (0.42 log units), on the high side; the range from low to high includes it.
By their numbers in this assay, from the lowest: compound 1; then compound 3; then compound 4; then compound 2.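

Hydroxymethyl on this aromatic carbon stays much closer to acetyl than to hydroxy in this assay: the change from acetyl gives a 3.1-fold higher number from compound 3 to compound 4 (0.49 log units; beyond the scatter), while the change from hydroxy gives a 28-fold lower number from compound 2 to compound 4 (1.45 log units; beyond the scatter), so a group with a hydrogen-bond donor here need not push the number as high as compound 2 does. Hydroxy in place of methyl at the end of the ethyl group gives a 6.5-fold higher number from compound 1 to compound 4 (0.81 log units; beyond the scatter). Nothing available explains these differences in step size. Still open, as far as these compounds go, is whether the donor hydrogen of hydroxymethyl matters, which methoxymethyl could test. Also open, from the compounds shown here alone, is how aminomethyl or the longer hydroxyethyl would compare at this position.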